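Open-chain analogues of a quinone lactone series

The compounds below may be only part of what the source reports. "The series", "measured", "known", "first", "only" and "open" are said of these compounds alone.

Measured so far:
compound 1 `COC1=C(OC)[C@H](OC(C)=O)[C@H](C/C=C(\C)CC/C=C(\C)C[C@H](O)/C=C(\C)C(=O)O)[C@@H](C)C1=O` in a functional assay on PC-3 cells (Homo sapiens) for inhibition, read by sulforhodamine B assay, with a stated time of 48 h (on this read-out higher numbers stand for weaker inhibition of growth and lower numbers for stronger inhibition of growth), gives > 30000 nM
compound 2 `COC1=C(OC)[C@H](OC(C)=O)[C@H](C/C=C(\C)CC/C=C(\C)C[C@@H]2C[C@@H](C)C(=O)O2)[C@@H](C)C1=O` in this assay gives > 30000 nM

The value for compound 1 is a limit of the assay and not a number. The value for compound 2 is likewise a limit and not a number. The change a step that the two limits leave unreadable from compound 1 to compound 2 is therefore not readable. Where compound 2 stands: the limit of > 30000 nM in this assay, at which 2 of the 2 values shown sit — both measured values rest at the same limit, so compound 2 is not distinguished from compound 1 in this assay.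

Compound 3 `COC1=C(OC)[C@H](OC(C)=O)[C@H](C/C=C(\C)CC/C=C(\C)C[C@H](O)C[C@@H](C)C(O)O)[C@@H](C)C1=O` differs from compound 2 by a group of 8 heavy atoms (5 carbon, 3 oxygen; no ring) in place of a group of 7 heavy atoms (5 carbon, 2 oxygen; one five-membered non-aromatic ring with 1 hetero atom), on a saturated chain carbon bound to a double-bonded chain carbon. Among the compounds with values here, the only measured step touching this position is a step that the two limits leave unreadable from compound 1 to compound 2, which gives no size and no direction, and no other step is known. The step expected from compound 2 to compound 3 is a step that the limit leaves unreadable from compound 2 to compound 3, with no direction beyond the scatter readable. Compound 3 is expected to give about 40000 nM in this assay, estimated between 10000 nM and 150000 nM, most probably reported again only as a limit.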

Compound 3, concentration for 50% growth inhibition: > 30000 nM
Compound 3 was reported as a limit (the forecaster's own chance of this, stated with the estimate: 85%); the middle value lies beyond the limit too.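

Compound 3 gives > 30000 nM in this assay, a limit and not a number. Within the data shown here, no step among compound 1, compound 2 and compound 3 can be read: the limit of > 30000 nM in this assay, at which 3 of the 3 values shown sit. From the compounds shown here alone, whether the group with the five-membered non-aromatic ring and the groups with no ring differ at all in this assay stays open.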